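From Methoxy to Azetidin-1-ylmethyl: Estimating Compound 4

The source may report more compounds than this note shows. Statements on the series, on what has been measured and on what is new or still open speak of the compounds shown alone.

Compound 1 `C[C@H](Nc1cc(F)c(S(=O)(=O)Nc2cscn2)cc1Cl)c1ccccc1F`: 410 nM
Compound 2 `C[C@H](Nc1cc(F)c(S(=O)(=O)Nc2cscn2)cc1Cl)c1cc(F)ccc1F`: 119 nM
Compound 3 `COc1ccc(F)c([C@H](C)Nc2cc(F)c(S(=O)(=O)Nc3cscn3)cc2Cl)c1`: 110 nM

All three were tested in an assay on HEK293 cells for inhibition of SCN8A/SCN1B (Homo sapiens), read by patch clamp, with a stated time of 20 min; on this read-out higher numbers stand for weaker inhibition and lower numbers for stronger inhibition. Compound 3 and compound 2 sit within the scatter of each other, as the step of a 1.1-fold lower number from compound 2 to compound 3 (0.03 log units; within the scatter) shows, and both stand well apart from compound 1: the steps of a 3.4-fold lower number from compound 1 to compound 2 (0.54 log units; beyond the scatter) and a 3.7-fold lower number from compound 1 to compound 3 (0.57 log units; beyond the scatter) are each beyond the scatter and of modest size. So compound 3 is one of two compounds that give the stronger numbers in this small set.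

Compound 4 `C[C@H](Nc1cc(F)c(S(=O)(=O)Nc2cscn2)cc1Cl)c1cc(CN2CCC2)ccc1F` carries the change ((azetidin-1-yl)methyl in place of methoxy on an aromatic carbon). Within the data shown here, no measured pair reproduces this change; the only steps that touch the same aromatic carbon are those from hydrogen to fluoro and from hydrogen to methoxy, which both gave a modest gain, while the exchange of methoxy for fluoro gave nothing beyond the scatter. On that basis the writer expects compound 4 to land near compound 3 with a wide band of uncertainty, an expected step of a 1.4-fold higher number from compound 3 to compound 4 (0.13 log units; within the scatter) that may fall within the scatter. The estimate for compound 4 in this assay is 150 nM, expected between 40 nM and 600 nM.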

Compound 4, half-maximal inhibitory concentration in the SCN8A/SCN1B assay: 120 nM
Estimate against measurement, compound 4: 1.3-fold (0.10 log units) above; the range from low to high includes it.
By their numbers in the SCN8A/SCN1B assay, from the lowest: compounds 3, 2 and 4 (each within the scatter of the next); then compound 1.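

In the SCN8A/SCN1B assay the aromatic carbon para to the fluoro group accepts (azetidin-1-yl)methyl, a group carrying a four-membered ring with a nitrogen, with no shift beyond the scatter from the two substituted compounds (a 1.1-fold higher number from compound 3 to compound 4 (0.04 log units; within the scatter); a 1.0-fold higher number from compound 2 to compound 4 (0.00 log units; within the scatter)). The advantage over the unsubstituted position also stays in place (a 3.4-fold lower number from compound 1 to compound 4 (0.53 log units; beyond the scatter)), so fluoro, methoxy and (azetidin-1-yl)methyl all read alike here, and only the hydrogen of compound 1 stands apart. Among these compounds, what the earlier compounds could not show is that this exchange leaves the inhibition number unchanged within the scatter while moving another property a long way, since in a physicochemical assay for lipophilicity, read by LC-MS, in phosphate buffer, measured as octanol-water partition, with a stated time of 1 h, at pH 7.4 (on this read-out higher numbers stand for higher lipophilicity and lower numbers for lower lipophilicity), the distribution coefficient falls sharply: the measured distribution coefficient of compound 3, 3.4, and of compound 4, 1.5, a number 1.90 log units lower (beyond the scatter). In the physicochemical assay compound 3 gives 3.4 and compound 4 gives 1.5.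

The compounds shown leave open whether a carboxylic acid, or an open-chain amine such as dimethylaminomethyl, would be accepted at this same aromatic carbon as well as the azetidine is. They also leave open whether the nitrogen of compound 4 matters at all to the number in the SCN8A/SCN1B assay, as a cyclobutylmethyl group, the same shape without that nitrogen, is not among them.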